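From compound 3 to compound 4: a carbamoyl swap

A few compounds are considered here, and "the series" means these few. Any claim that something is new, unique, unknown or untested is made for them only; others in the source may bear on it.

In a functional assay on A549 cells (Homo sapiens) for antiproliferative activity, read by sulforhodamine B assay, with a stated time of 3 days (a higher number here means a weaker inhibitor of growth, a lower number a stronger inhibitor of growth), compound 3 `CN(C)CC(=O)Nc1cccc(Nc2ncc(F)c(Nc3ccc(F)cc3)n2)c1` gives 1180 nM and compound 1 `CN1CCC(C(=O)Nc2cccc(Nc3ncc(F)c(Nc4ccc(F)cc4)n3)c2)CC1` gives 1330 nM, which is a 1.1-fold lower number from compound 1 to compound 3 (0.05 log units; within the scatter). Compound 2 `Cn1ccnc1NC(=O)c1cccc(Nc2ncc(F)c(Nc3ccc(F)cc3)n2)c1` stands apart at 10100 nM, and the return is an 8.6-fold lower number from compound 2 to compound 3 (0.93 log units; beyond the scatter).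

Compound 4 `O=C(NCCO)c1cccc(Nc2ncc(F)c(Nc3ccc(F)cc3)n2)c1` has (2-hydroxyethyl)carbamoyl in place of (((dimethylamino)methyl)carbonyl)amino on an aromatic carbon. Compound 2 is the only measured carbamoyl, though its side chain differs, so a 7.6-fold higher number from compound 1 to compound 2 (0.88 log units; beyond the scatter) is the nearest guide. A move of similar direction but perhaps smaller size is expected in this assay.

The estimated step is a 4.2-fold higher number from compound 3 to compound 4 (0.63 log units; beyond the scatter).

For compound 4 the estimate is 5000 nM, with an expected range of 1500 nM to 15000 nM.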

Compound 4, concentration for 50% growth inhibition: 11900 nM
Compound 4: middle estimate off by 2.4-fold (0.38 log units), on the low side; the measured number falls inside the stated range.
By their numbers in this assay, from the lowest: compounds 3 and 1 (each within the scatter of the next); then compounds 2 and 4 (each within the scatter of the next).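

In this assay, 2-hydroxyethyl in place of 1-methyl-1H-imidazol-2-yl on the amide-type nitrogen gives a 1.2-fold higher number from compound 2 to compound 4 (0.07 log units; within the scatter) and does not separate these two carbamoyl compounds. The steps of a 10-fold higher number from compound 3 to compound 4 (1.00 log units; beyond the scatter) and an 8.9-fold higher number from compound 1 to compound 4 (0.95 log units; beyond the scatter) put compound 4 with compound 2, so among the compounds shown, both carbamoyl groups on this aromatic carbon give higher numbers than both carbonylamino groups. No measurement shown here gives a reason for this gap.

The amide direction and the amine in the side chain change together across these compounds. A (2-(dimethylamino)ethyl)carbamoyl group would separate the two.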